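The compounds below may be only part of what the source reports. "The series", "measured", "known", "first", "only" and "open" are said of these compounds alone.

Compound 1 `CC(C)[C@H](NC(=O)COc1cccc2ccccc12)C(=O)N[C@@H](CC(=O)O)C(=O)COC(=O)c1c(Cl)cccc1Cl` carries the shared core with a (2,6-dichlorophenyl)carbonyl on an oxygen on a saturated carbon; in a functional assay on Jurkat cells (Homo sapiens) (a higher number here means a weaker inhibitor, a lower number a stronger inhibitor), compound 1 gives 10600 nM. Compound 2 `CC(C)[C@H](NC(=O)COc1cccc2ccccc12)C(=O)N[C@@H](CC(=O)O)C(=O)COc1cccc(F)c1` has 3-fluorophenyl in that place. In this assay compound 2 reaches only > 100000 nM, which is a limit of the assay and not a number. The step is an at least 9.4-fold higher number from compound 1 to compound 2 (0.97 log units; beyond the scatter), read against (the limit of > 100000 nM in this assay, at which 1 of the 2 values shown sits). Compound 3 `CC(C)[C@H](NC(=O)COc1cccc2ccccc12)C(=O)N[C@@H](CC(=O)O)C(=O)COc1c(F)cc(F)cc1F` differs from compound 2 in one place: 2,4,6-trifluorophenyl in place of 3-fluorophenyl on an oxygen on a saturated carbon. Within the data shown here, no measured step covers this exchange; the only known step, an at least 9.4-fold higher number from compound 1 to compound 2 (0.97 log units; beyond the scatter), concerns a different group at the same oxygen. Compound 2 stands at the limit, so a further loss could not register and only a gain would show. With no guide from the measured compounds, compound 3 is expected to stay near compound 2, an expected step of an at least 1.6-fold lower number from compound 2 to compound 3 (0.22 log units; that floor lies within the scatter). The estimate for compound 3 in this assay is 60000 nM, within 15000 nM to 200000 nM.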

Compound 3, half-maximal inhibitory concentration: 6840 nM
Beside the measured number, compound 3's estimate is 8.8-fold (0.94 log units) above it, and the stated range ends above it.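

In this assay, the exchange of 3-fluorophenyl for 2,4,6-trifluorophenyl on this oxygen gives an at least 14-fold lower number from compound 2 to compound 3 (1.16 log units; beyond the scatter), so the substitution on the phenyl group decides whether inhibition registers at all. The true size of that step stays unknown, as the value of compound 2 is a limit and not a number: the limit of > 100000 nM in this assay, at which 1 of the 3 values shown sits.

The earlier pair left it open whether any phenyl group could stand in for the (2,6-dichlorophenyl)carbonyl, but the exchange that gives a 1.5-fold lower number from compound 1 to compound 3 (0.19 log units; within the scatter) shows that 2,4,6-trifluorophenyl can take its place with no difference beyond the scatter.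

The compounds shown cannot separate the number of fluorine atoms from where they sit on the ring. As far as these compounds go, how an unsubstituted phenyl or a 2,4,6-trichlorophenyl group would read at this oxygen also remains open.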